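Swapping the Amide Aryl Group in a Hedgehog Inhibitor Series

The compounds below may be only part of what the source reports. "The series", "measured", "known", "first", "only" and "open" are said of these compounds alone.

For the measured compounds named here, compound 2 `O=C(Nc1ccc(Cl)c(-c2ccccn2)c1)c1ccncc1` is the weaker of the two measured members here. In an assay on C3H 10T1/2 cells for inhibition of Sonic hedgehog protein (Mus musculus), read by a luciferase reporter (on this read-out higher numbers stand for weaker inhibition and lower numbers for stronger inhibition), compound 2 gives 700 nM, whereas compound 1 `Cc1ccc(C(=O)Nc2ccc(Cl)c(-c3ccccn3)c2)c(C)n1` gives 130 nM. Going by the values given here, the only measured step, a 5.4-fold higher number from compound 1 to compound 2 (0.73 log units; beyond the scatter), shows that changing the aromatic group attached to the carbonyl carbon shifts the number by a modest but real amount. Compound 3 `O=C(Nc1ccc(Cl)c(-c2ccccn2)c1)c1ccccc1Cl` alters the same position: 2-chlorophenyl in place of pyridin-4-yl on a carbonyl carbon. Among the compounds with values here, no measured pair shows this exact exchange, so the expectation rests on the single step from compound 1 to compound 2, which indicates that this position tolerates a change of ring and that the pyridin-4-yl variant was the weaker of the two. A return toward stronger inhibition is plausible but uncertain. For compound 3 the estimated value in this assay is 300 nM, with a range from 80 nM to 1500 nM. That amounts to an expected step of a 2.3-fold lower number from compound 2 to compound 3 (0.37 log units; beyond the scatter).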

Compound 3, half-maximal inhibitory concentration: 110 nM
The estimate for compound 3 lay 2.7-fold (0.44 log units) above the measured number; low and high end bracket the measured number.
By their numbers in this assay, from the lowest: compounds 3 and 1 (each within the scatter of the next); then compound 2.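

Putting 2-chlorophenyl in place of pyridin-4-yl on this carbonyl carbon gives a 6.4-fold lower number from compound 2 to compound 3 (0.80 log units; beyond the scatter) and shows that a ring of carbon only can serve here, so a ring nitrogen is not needed for a low number in this assay. The comparison with the other substituted ring gives a 1.2-fold lower number from compound 1 to compound 3 (0.07 log units; within the scatter) and so 2-chlorophenyl and 2,6-dimethylpyridin-3-yl cannot be told apart, although they differ in their ring atoms and in what the ring carries. Nothing measured here explains why the exchange of pyridin-4-yl for 2-chlorophenyl moves the number.

Still open, on these data alone, is how a plain phenyl ring would compare with 2-chlorophenyl, a comparison that would separate the effect of the chlorine from that of the ring itself. Also open, as far as these compounds go, is whether this position accepts a ring bearing an amine or a carboxylic acid.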